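Aminohexyl in place of aminophenyl on the shared core

This account rests on a few compounds, and the source may have more. Where it says the series, first, only, none or still open, it means among the compounds named here.

compound 1 `Nc1ccc(Nc2c(C(=O)NCc3ccc(F)cc3)nc(Br)c3cccnc23)cc1` — 7000 nM
compound 2 `NCCCNc1c(C(=O)NCc2ccc(F)cc2)ncc2cccnc12` — 16000 nM

In a functional assay on MDA-MB-435 cells (Homo sapiens) for cytotoxicity, read by MTT assay, with a stated time of 72 h (a higher number here means a weaker inhibitor, a lower number a stronger inhibitor), compound 1 gives 7000 nM, the lowest of the two numbers. Compound 2 gives 16000 nM, a gap beyond the scatter, but the two differ in more than one place, so no single step can be read from them. Compound 3 `NCCCCCCNc1c(C(=O)NCc2ccc(F)cc2)nc(Br)c2cccnc12` carries the change (6-aminohexyl in place of 4-aminophenyl on a nitrogen on an aromatic ring). Compound 2, which also lacks the 4-aminophenyl and stands weaker than compound 1, gives a loose pointer toward some loss. A small step beyond the scatter is expected, estimated as a 1.6-fold higher number from compound 1 to compound 3 (0.20 log units; within the scatter). Compound 3 is expected at 11000 nM, with a range from 4500 nM to 28000 nM.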

Compound 3, half-maximal inhibitory concentration: 6000 nM
For compound 3 the middle estimate is 1.8-fold (0.26 log units) above the measured one; the measured number falls inside the stated range.
By their numbers in this assay, from the lowest: compounds 3 and 1 (each within the scatter of the next); then compound 2.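

In this assay, 6-aminohexyl in place of 4-aminophenyl on a nitrogen on an aromatic ring gives a 1.2-fold lower number from compound 1 to compound 3 (0.07 log units; within the scatter). At this position, an open chain with no ring therefore stands within the scatter of the aromatic group, so the ring is not required for this level of cytotoxicity. No measurement at hand bears on this result. Steps involving compound 2 cannot be read, as it differs from the others in more than one place. Open, going by these compounds, is whether a carboxylic acid in place of the terminal amine, or a longer chain, would hold this level.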